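The compounds below may be only part of what the source reports. "The series", "measured", "known", "first", "only" and "open" are said of these compounds alone.

Measured compounds:
- compound 1 `C=CC(=O)Nc1cccc(Nc2nc(Cl)nc(Nc3ccc(OCCOC)cc3)n2)c1`: "not determined" (no result reported)
- compound 2 `C=CC(=O)Nc1cccc(Nc2nc(N)nc(Nc3ccc(Oc4ccccc4)cc3)n2)c1`: 20000 nM
- compound 3 `C=CC(=O)Nc1cccc(Nc2ncnc(Nc3ccc(C(=O)Nc4ccccn4)cc3)n2)c1`: "not determined" (no result reported)

All three share a common core carrying an acrylamide group, and all were examined in a functional assay on Ramos cells (Homo sapiens) for antiproliferative activity, read by CCK-8 assay, with a stated time of 24 h; a lower number here means a stronger inhibitor, a higher number a weaker inhibitor. For compound 1 and compound 3 no number was recorded. For the measured compounds named here, compound 2 is therefore the only compound with a measured value, and in this assay compound 2 gives 20000 nM, a weak result in absolute terms. Going by the values given here, with nothing to compare it against, no step between measured compounds can be drawn.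

Compound 4 `C=CC(=O)Nc1cccc(Nc2nc(N)nc(Nc3ccc(OCCOC)cc3)n2)c1` is the compound still to be measured. It differs from compound 2 in one place: 2-methoxyethyl in place of phenyl on an oxygen on an aromatic ring. Among the compounds with values here, since no measured pair shows the effect of this change, the expectation for compound 4 in this assay is a step of no change at the digits printed from compound 2 to compound 4 (within the scatter), that is, no change beyond the usual scatter. Compound 4 is accordingly estimated at 20000 nM, with a plausible range from 7000 nM to 60000 nM.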

Compound 4, half-maximal inhibitory concentration: 18900 nM
Compound 4: the middle estimate sits 1.1-fold (0.02 log units) above what was measured; low and high end bracket the measured number.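

For the compounds shown here, this is the first pair that differs in one place, and in this assay putting 2-methoxyethyl in place of phenyl on an oxygen on an aromatic ring gives a 1.1-fold lower number from compound 2 to compound 4 (0.02 log units; within the scatter). At this place, then, an open chain that carries a hydrogen-bond acceptor reads the same as a six-membered aromatic ring without one, so the assay does not separate the two groups and the aromatic ring is not required to keep this level of activity. No supporting measurement is available to explain why the two groups read alike.

From the compounds shown here alone, whether any other kind of group at this place would shift the number remains open, for example a carboxylic acid or a longer chain ending in an amine. Also open, going by these compounds, is whether the weak activity of both compounds depends on this place at all, or on the rest of the shared core.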